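A Methyl Added to the Ethoxycarbonyl Group

A few compounds are considered here, and "the series" means these few. Any claim that something is new, unique, unknown or untested is made for them only; others in the source may bear on it.

In an ADME assay on BJ cells (Homo sapiens) for cytotoxicity, with a stated time of 72 h (a lower number here means that less compound is needed, a higher number that more compound is needed for the effect), compound 1 `CCN(CC)C(=O)COc1cc2c(-n3nc(-c4ccccn4)nc3N)ncnc2cc1OC` gives > 25000 nM as a limit only. Compound 2 `COc1cc2ncnc(-n3nc(-c4ccccn4)nc3N)c2cc1OCCNC(=O)OC(C)(C)C` gives > 15000 nM as a limit too. Compound 3 `CCOC(=O)NCCCOc1cc2c(-n3nc(-c4ccccn4)nc3N)ncnc2cc1OC` likewise reaches only a limit (> 11000 nM), and the other two values shown are limits as well.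

Compound 4 `COc1cc2ncnc(-n3nc(-c4ccccn4)nc3N)c2cc1OCCCNC(=O)OC(C)C` differs from compound 3 by a single change (methyl in place of hydrogen on a saturated chain carbon bound to an oxygen next to a carbonyl group and a saturated chain carbon): methyl in place of hydrogen on a saturated chain carbon bound to an oxygen next to a carbonyl group and a saturated chain carbon. The same difference reads as ethoxycarbonyl to isopropoxycarbonyl.

The closest comparison is a step that the two limits leave unreadable from compound 2 to compound 3 with ((ethoxycarbonyl)amino)methyl in place of (tert-butoxycarbonyl)amino. Two further comparisons are a step that the two limits leave unreadable from compound 1 to compound 2 and a step that the two limits leave unreadable from compound 1 to compound 3 and both start from diethylcarbamoyl. None of the three gives a size, so no step beyond the scatter is expected in this assay and no direction can be named.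

The expected step is a step that the limit leaves unreadable from compound 3 to compound 4 and it remains an estimate. For compound 4 the estimated value is 15000 nM with an expected range from 7000 nM to 35000 nM. Compound 4 is expected to give a limit again.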

Compound 4, half-maximal effective concentration: > 13000 nM
Compound 4 gave a limit, no number (the forecaster's own chance of this, stated with the estimate: 80%); the middle value does not contradict the limit.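

In this assay compound 4 gives > 13000 nM, a limit and not a number. Compound 3 also gives only a limit, > 11000 nM. Going by these compounds alone, no step from compound 1, compound 2 or compound 3 to compound 4 can be read. The compounds shown leave open what the half-maximal effective concentration of any of them is, and whether ethoxycarbonyl to isopropoxycarbonyl alters it.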